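The source may report more compounds than this note shows. Statements on the series, on what has been measured and on what is new or still open speak of the compounds shown alone.

Compound 2, `CC(=O)c1ccc(Nc2ccnc(SCC(=O)c3ccc(Cl)cc3)n2)cc1`, gives 46% in a functional assay on RPMI-8226 cells (Homo sapiens) for inhibition, read by sulforhodamine B assay, with a stated time of 48 h, tested at 10 uM; on this read-out lower numbers stand for less inhibition of growth and higher numbers for more inhibition of growth at the one concentration tested. Compound 1, `CC(=O)c1cccc(Nc2ccnc(SCC(=O)c3ccc(-c4ccccc4)cc3)n2)c1`, gives 34%.

Compound 2 holds the higher of these two numbers, and its gap to compound 1 is beyond the usual scatter. The two differ in more than one place, so nothing can be pinned on a single change. Compound 3, `CC(=O)c1ccc(Nc2ccnc(SCC(=O)c3ccc(-c4ccccc4)cc3)n2)cc1`, arises from compound 2 by phenyl in place of chloro on an aromatic carbon. Among the measured compounds shown here, no step of this kind has been measured here. Because compound 1, which also carries the phenyl, gives 34%, a small downward move in this assay is expected, though it could well stay within the scatter. Compound 3 is estimated at 39%, within 22% to 56%, an expected step of a number 7 percentage points lower from compound 2 to compound 3 (within the scatter).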

Compound 3, percent growth inhibition at one concentration: 26%
Beside the measured number, compound 3's estimate is 13 percentage points above it, and the stated range covers the measured number.
By their numbers in this assay, from the lowest: compounds 3 and 1 (each within the scatter of the next); then compound 2.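

In this assay, among the compounds shown here, phenyl in place of chloro on an aromatic carbon, para to a large group, gives a number 20 percentage points lower from compound 2 to compound 3 (beyond the scatter), the first single-place reading at this position: here the larger group goes with less inhibition of growth. With phenyl held fixed, 4-acetylphenyl in place of 3-acetylphenyl on a nitrogen gives a number 8 percentage points lower from compound 1 to compound 3 (within the scatter), so this swap does not stand out from the scatter. Nothing shown here gives a reason for either result.

Open, as far as these compounds go, is how a methoxy group or an amine at this position would compare with chloro and phenyl. Also open, from the compounds shown here alone, is whether the acetyl swap would count for more with chloro in place.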